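The source may report more compounds than this note shows. Statements on the series, on what has been measured and on what is new or still open speak of the compounds shown alone.

For the measured compounds named here, in a functional assay on SGC-7901 cells (Homo sapiens) for antiproliferative activity, read by MTT assay, with a stated time of 24 h (on this read-out higher numbers stand for weaker inhibition and lower numbers for stronger inhibition), compound 1 (`O=C(NNc1ccccc1Cl)c1ccc(NS(=O)(=O)c2cnc(O)nc2O)cc1`) gives 3630 nM, the only true number so far. Compound 2 (`Cc1cccc(NNC(=O)c2ccccc2NS(=O)(=O)c2cnc(O)nc2O)c1`) reads > 20000 nM, which is a limit. Compound 3 (`O=C(NNc1ccccc1F)c1ccccc1NS(=O)(=O)c1cnc(O)nc1O`) reads > 20000 nM, also a limit. Going by the values given here, the sole measured step, a step that the two limits leave unreadable from compound 2 to compound 3, offers no size to carry over, and the remaining evidence is the limit of > 20000 nM in this assay, at which 2 of the 3 values shown sit.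

Compound 4 (`O=C(NNC(=O)c1ccccc1Cl)c1ccc(NS(=O)(=O)c2cnc(O)nc2O)cc1`) has (2-chlorophenyl)carbonyl in place of 2-chlorophenyl on an amine nitrogen. Among the compounds with values here, no measured step covers this change, so only a modest loss is expected in this assay, with wide uncertainty. The expected change is a 1.7-fold higher number from compound 1 to compound 4 (0.22 log units; within the scatter), toward weaker inhibition. For compound 4 the estimate is 6000 nM, with an expected range of 1500 nM to 20000 nM.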

Compound 4, half-maximal inhibitory concentration: 3240 nM
Compound 4: the middle estimate sits 1.9-fold (0.27 log units) above what was measured; the range from low to high includes it.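

In this assay, for the compounds shown here, (2-chlorophenyl)carbonyl in place of 2-chlorophenyl on an amine nitrogen gives a 1.1-fold lower number from compound 1 to compound 4 (0.05 log units; within the scatter), the first step of readable size. This nitrogen therefore carries the added carbonyl, with the six-membered aromatic ring kept, without a shift beyond the scatter; the step between the two limit compounds cannot be read. Still open, as far as these compounds go, is whether a group without that ring, such as a longer alkyl chain or a carboxylic acid, holds the number on this nitrogen. The remaining readings give no size: the limit of > 20000 nM in this assay, at which 2 of the 4 values shown sit.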